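The source may report more compounds than this note shows. Statements on the series, on what has been measured and on what is new or still open speak of the compounds shown alone.

Measured to date:
compound 1 `CC(C)c1nc2c(C(=O)NCC3CCN(CCN4CCN(S(C)(=O)=O)CC4)CC3)cccc2[nH]1` – 0.794 nM
compound 2 `COC(=O)N1CCN(CCN2CCC(CNC(=O)c3cccc4[nH]c(C(C)C)nc34)CC2)CC1` – 1.59 nM

In an assay on isolated protein for binding affinity to 5-hydroxytryptamine receptor 4 (Homo sapiens) (a lower number here means a stronger inhibitor, a higher number a weaker inhibitor), compound 1 gives 0.794 nM and compound 2 gives 1.59 nM. Within the data shown here, compound 2 holds the higher of the two numbers, but its only neighbour is compound 1, and the step of a 2.0-fold higher number from compound 1 to compound 2 (0.30 log units; within the scatter) lies within the scatter, so the two compounds cannot be separated on these numbers.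

The next compound, compound 3 `CC(=O)N1CCN(CCN2CCC(CNC(=O)c3cccc4[nH]c(C(C)C)nc34)CC2)CC1`, keeps the shared core and the amine-bearing side chain of compound 2 and differs from it by methyl in place of methoxy on a carbonyl carbon. Among the measured compounds shown here, the only step on record, a 2.0-fold higher number from compound 1 to compound 2 (0.30 log units; within the scatter), exchanged the whole group on the same ring nitrogen, methylsulfonyl for methoxycarbonyl, and stayed within the scatter. For the measured compounds named here, no measured step touches the carbonyl substituent itself, so the change from methoxycarbonyl to acetyl is uncharted; the one related step gives no ground to expect a move beyond the scatter in this assay.

Compound 3 is therefore expected near 1.4 nM, in the range 0.5 nM to 4 nM. The expected step of a 1.1-fold lower number from compound 2 to compound 3 (0.06 log units; within the scatter) amounts to no more than the scatter.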

Compound 3, inhibition constant: 5.01 nM
Compound 3: the middle estimate sits 3.6-fold (0.55 log units) below what was measured; measured number outside the range, above it.
By their numbers in this assay, from the lowest: compounds 1 and 2 (each within the scatter of the next); then compound 3.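

In this assay, the group on the carbonyl carbon attached to the amide-type ring nitrogen proves able to shift the number on its own: methyl in place of methoxy gives a 3.2-fold higher number from compound 2 to compound 3 (0.50 log units; beyond the scatter) with the rest of the structure unchanged, whereas the exchange of methylsulfonyl for methoxycarbonyl on that same nitrogen stayed within the scatter. Acetyl also separates from methylsulfonyl (a 6.3-fold higher number from compound 1 to compound 3 (0.80 log units; beyond the scatter)), so 4-acetylpiperazin-1-yl stands apart from the other two groups at this place in the side chain, while those two remain inseparable. The compounds shown show the size of this change but offer no measurement that accounts for it.

Open, going by these compounds, is whether the higher number belongs to acetyl alone or extends to other groups on the same ring nitrogen, such as propanoyl, ethoxycarbonyl or dimethylaminocarbonyl, which would show how far the methoxy oxygen can be replaced or moved. Also open, on these data alone, is whether the order of these three groups holds when the shared core changes, since all three compounds carry it unaltered.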